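A few compounds are considered here, and "the series" means these few. Any claim that something is new, unique, unknown or untested is made for them only; others in the source may bear on it.

Working notes on the series. Among the compounds with values here, in a functional assay on CCRF-CEM cells (Homo sapiens) for antiproliferative activity (a lower number here means a stronger inhibitor of growth, a higher number a weaker inhibitor of growth), compound 1 `COCCCCCCCCCCC/C=C1\CC(CO)(COC(=O)C(C)(C)C)OC1=O` gives 0.701 ug/mL, the lowest number measured so far. Compound 2 `CCCCCCCCC(O)CCCCCC/C=C1\CC(CO)(COC(=O)C(C)(C)C)OC1=O` gives 5.72 ug/mL. Compound 3 `CC(C)(C)C(=O)OCC1(CO)C/C(=C/CCCCCCCCCCCCCCC=O)C(=O)O1` gives > 10 ug/mL, which is a limit and not a number. Compound 4 `CC(C)(C)C(=O)OCCCCCCCCCCCCCCC/C=C1\CC(CO)(COC(=O)C(C)(C)C)OC1=O` has not yet been measured. Its change from compound 1 is 4-(((tert-butyl)carbonyl)oxy)butyl in place of methoxy on a saturated chain carbon, ten or more bonds along the chain from a double-bonded chain carbon. Within the data shown here, the only measured step on the chain is an 8.2-fold higher number from compound 1 to compound 2 (0.91 log units; beyond the scatter), so a rise of similar size is expected in this assay. The expected step is a 4.3-fold higher number from compound 1 to compound 4 (0.63 log units; beyond the scatter). For compound 4 the estimated value is 3 ug/mL, with an expected range of 0.7 ug/mL to 12 ug/mL.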

Compound 4, concentration for 50% growth inhibition: > 10 ug/mL
Compound 4 was reported as a limit; the forecaster's own chance of this, stated with the estimate: 20%; middle value at least 3.3-fold (0.52 log units) away from the limit.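

In this assay, a change at the far end of the chain still moves the result, giving an at least 14-fold higher number from compound 1 to compound 4 (1.15 log units; beyond the scatter). The value of compound 4, > 10 ug/mL, is a limit and not a number. This position therefore does not accept 4-(((tert-butyl)carbonyl)oxy)butyl in place of methoxy without loss, and compound 4 joins the compounds at the assay ceiling: the limit of > 10 ug/mL in this assay, at which 2 of the 4 values shown sit.

On these data alone, whether the pivalate ester or the added chain length drives the loss remains open, since a plain alkyl chain of matching length would be needed to separate them. As far as these compounds go, how a terminal amine or carboxylic acid behaves at this position also remains open.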